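Benzyl in place of 3,4-dihydroxyphenyl: two matched pairs

The source may report more compounds than this note shows. Statements on the series, on what has been measured and on what is new or still open speak of the compounds shown alone.

Measured compounds:
compound 1 `O=C(NCCNS(=O)(=O)c1ccc(-c2ccccc2Oc2ccc(O)c(O)c2)s1)Nc1cc(Cl)cc(Cl)c1` — 4500 nM
compound 2 `O=C(NCCNS(=O)(=O)c1ccc(-c2ccccc2OCc2ccccc2)s1)Nc1cc(Cl)cc(Cl)c1` — > 20000 nM, a limit of the assay
compound 3 `O=C(NCCNS(=O)(=O)c1ccc(-c2ccccc2Oc2ccc(O)c(O)c2)s1)Nc1cc(C(F)(F)F)cc(C(F)(F)F)c1` — 4900 nM

In a functional assay on RS4-11 cells (Homo sapiens) for inhibition, read by CCK-8 assay, with a stated time of 48 h (on this read-out higher numbers stand for weaker inhibition and lower numbers for stronger inhibition), compound 1 gives 4500 nM. Compound 2 differs from it by benzyl in place of 3,4-dihydroxyphenyl on an oxygen on an aromatic ring. In this assay compound 2 reaches only > 20000 nM, which is a limit of the assay and not a number. The step of an at least 4.4-fold higher number from compound 1 to compound 2 (0.64 log units; beyond the scatter) can therefore be given only as a lower bound, because of the limit of > 20000 nM in this assay, at which 1 of the 3 values shown sits.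

Compound 3 carries a different core; the difference between the core of compound 1 and the core of compound 3 is not broken down here. In this assay compound 3 gives 4900 nM, within the scatter of compound 1, so the two cores cannot be separated on this read-out.

Compound 4 `O=C(NCCNS(=O)(=O)c1ccc(-c2ccccc2OCc2ccccc2)s1)Nc1cc(C(F)(F)F)cc(C(F)(F)F)c1` is not yet measured. It stands to compound 3 as compound 2 stands to compound 1, with benzyl in place of 3,4-dihydroxyphenyl on an oxygen on an aromatic ring. The place of the change is the same word for word in both pairs, so this is the same change, made for the second time in the series.

Among the compounds with values here, the expectation rests on the single precedent an at least 4.4-fold higher number from compound 1 to compound 2 (0.64 log units; beyond the scatter) and on the starting point of compound 3 at 4900 nM. A step of about a 5.1-fold higher number from compound 3 to compound 4 (0.71 log units; beyond the scatter) is expected in this assay. For compound 4 the estimate in this assay is 25000 nM, expected to lie between 10000 nM and 60000 nM, with a good chance that the assay again reports only a limit.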

Compound 4, half-maximal inhibitory concentration: > 50000 nM
Compound 4: a limit, no number; the forecaster's own chance of this, stated with the estimate: 70%; middle value at least 2.0-fold (0.30 log units) away from the limit.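

In this assay compound 4 gives > 50000 nM, a limit of the assay and not a number. The new step, an at least 10-fold higher number from compound 3 to compound 4 (1.00 log units; beyond the scatter), has the same direction as the earlier one, so on both cores benzyl in place of 3,4-dihydroxyphenyl goes with weaker inhibition: the same change on two cores in this assay, an at least 4.4-fold higher number (0.64 log units; beyond the scatter) from compound 1 to compound 2 and an at least 10-fold higher number (1.00 log units; beyond the scatter) from compound 3 to compound 4; the limit leaves it open whether they differ This shows that the loss carries over from the core of compound 1 to the core of compound 3, but with both benzyl compounds at limits it gives no actual size of the loss on either core, and two cores do not make a rule for the wider series.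

Going by these compounds, the change from 3,4-dihydroxyphenoxy to benzyloxy swaps the ring substituents and the link to the ring in one step, so it remains open whether the loss follows the two hydroxyl groups, the added carbon, or both. A plain phenyl or a 3,4-dihydroxybenzyl on the same oxygen would separate these two parts, and a carboxylic acid or an amine on the ring would show whether groups other than hydroxyl can take their place.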